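Meta-Substituted Phenylurea Series: Whole-Organism Read-Out

The compounds below may be only part of what the source reports. "The series", "measured", "known", "first", "only" and "open" are said of these compounds alone.

Measured compounds:
compound 1, `CCOC(=O)c1cccc(NC(=O)N[C@H](C)c2ccccc2)c1`, 88%
compound 2, `COc1cccc(NC(=O)N[C@H](C)c2ccccc2)c1`, 70%

In an ADME assay on the whole organism with Oryza sativa as the target, tested at 10 uM (on this read-out higher numbers stand for a weaker effect at the one concentration tested and lower numbers for a stronger effect), compound 1 gives 88% and compound 2 gives 70%. For the measured compounds named here, the one measured step, a number 18 percentage points lower from compound 1 to compound 2 (beyond the scatter), is a modest change beyond the scatter. Compound 2 stands lowest of the two numbers in this assay, with compound 1 nearest and higher.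

Compound 3, `C[C@@H](NC(=O)Nc1cccc(F)c1)c1ccccc1`, is not yet measured in this assay. Its change from compound 2 is fluoro in place of methoxy on an aromatic carbon, at the same site on the ring, meta to a large group.

Going by the values given here, no measured step replaces methoxy by fluoro; the only step known, a number 18 percentage points lower from compound 1 to compound 2 (beyond the scatter), concerns a different pair of groups at that site and gives a modest change. Nothing in the two values indicates how fluoro at this position should read, so no direction is favoured and a step within the scatter is the expectation; the estimated step is a number 2 percentage points higher from compound 2 to compound 3 (within the scatter). Compound 3 is therefore expected to give about 72% in this assay, with a range from 52% to 90%.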

Compound 3, a percentage reported as activity, at one concentration (the size of the read-out at that concentration, not a potency): 84%
Beside the measured number, compound 3's estimate is 12 percentage points below it, within the range that was stated.
By their numbers in this assay, from the lowest: compound 2; then compounds 3 and 1 (each within the scatter of the next).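

Working notes on the site on the aromatic carbon, meta to a large group: in this assay the change of methoxy to fluoro is not neutral, with a number 14 percentage points higher from compound 2 to compound 3 (beyond the scatter) as the measured step, so this site responds to more than the one exchange seen earlier. For the compounds shown here, the step of a number 4 percentage points lower from compound 1 to compound 3 (within the scatter) places fluoro and ethoxycarbonyl together on this read-out, which leaves methoxy as the only one of the three groups whose compound is set apart beyond the scatter from both others, and compound 2 as the lowest of the three. No supporting data bear on why methoxy reads differently from the other two groups at this site.

The compounds shown leave open whether the lower number is particular to methoxy or is shared by close relatives such as ethoxy, hydroxy or a longer alkoxy chain, and where groups of another kind, such as an amine, a carboxylic acid or chloro, would fall at the same site. They also leave open whether methoxy would read the same way elsewhere on the ring, since all three groups sit at this one site.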